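The source may hold more compounds than are shown below. What is called first, only, known or untested is meant among the compounds shown, and "the series" means these compounds.

Compound 1 `O=C([C@@H]1CCCN(S(=O)(=O)c2ccc(S(=O)(=O)N3CC[C@@H](O)C3)cc2)C1)N1CCC(F)(F)CC1` — 330 nM
Compound 2 `CCN(CC)S(=O)(=O)c1ccc(S(=O)(=O)N2CCC[C@@H](C(=O)NC3COC3)C2)cc1` — 13800 nM
Compound 3 `CCN(CC)C(=O)c1ccc(S(=O)(=O)N2CCC[C@@H](C(=O)N3CCC(F)(F)CC3)C2)cc1` — 240 nM

In a functional assay on BXPC-3 cells (Homo sapiens) for inhibition, read by MTT assay, with a stated time of 7 days (a lower number here means a stronger inhibitor, a higher number a weaker inhibitor), compound 2 stands highest of the three, and its distance to compound 1 and to compound 3 lies beyond the scatter in each case, so compound 2 is the weakest inhibitor of this set. Compound 4 `CCN(CC)S(=O)(=O)c1ccc(S(=O)(=O)N2CCC[C@@H](C(=O)N3CCC(COC)CC3)C2)cc1` has not been measured; it differs from compound 2 by 4-(methoxymethyl)piperidin-1-yl in place of (oxetan-3-yl)amino on a carbonyl carbon. Going by the values given here, only one step is available among the measured compounds, a 1.4-fold lower number from compound 1 to compound 3 (0.14 log units; within the scatter), and it concerns the aromatic carbon rather than the carbonyl carbon, so it says nothing direct about the change at hand. Among the compounds with values here, compounds 1 and 3 differ from compound 2 in two places at once, so no single step can be separated; what their values show is that the two compounds carrying a six-membered ring with one hetero atom on the carbonyl carbon sit far lower than compound 2. Compound 4 brings in such a ring, so a large downward step is expected, a 20-fold lower number from compound 2 to compound 4 (1.29 log units; beyond the scatter), and compound 4 is estimated at 700 nM with a range from 200 nM to 2500 nM.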

Compound 4, half-maximal inhibitory concentration: 1360 nM
Compound 4: middle estimate off by 1.9-fold (0.29 log units), on the low side, and the stated range covers the measured number.
By their numbers in this assay, from the lowest: compounds 3 and 1 (each within the scatter of the next); then compound 4; then compound 2.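

In this assay, the carbonyl carbon now has a step that can be read on its own, a 10-fold lower number from compound 2 to compound 4 (1.01 log units; beyond the scatter), whereas compounds 1 and 3 differed from compound 2 in two places at once. Going by these compounds alone, the position therefore responds to this change alone, and the step lies beyond the scatter, unlike the only step at the aromatic carbon, a 1.4-fold lower number from compound 1 to compound 3 (0.14 log units; within the scatter). No measurement available here accounts for the size of the step.

The change replaces a four-membered ring with a six-membered one, removes the amide hydrogen and adds the methoxymethyl chain, all together, so the compounds shown cannot tell these apart. On these data alone, an unsubstituted piperidin-1-yl or a dimethylamino group on the same carbonyl carbon remains untested among them.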